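The compounds below may be only part of what the source reports. "The series", "measured", "known", "first", "only" and "open" are said of these compounds alone.

Compound 1 `O=C(O)c1cn(C2CC2)c2nc(N3CCN(C(c4ccccc4)c4ccc(Cl)cc4)CC3)c([N+](=O)[O-])cc2c1=O` and compound 2 `O=C(O)c1cn(C2CC2)c2nc(N3CCN(C(=O)C4COc5ccccc5O4)CC3)c([N+](=O)[O-])cc2c1=O` carry different cores; the difference between the two cores is not broken down here. In an ADME assay on Vero cells (Chlorocebus sabaeus) for cytotoxicity, read by MTT assay, with a stated time of 72 h (a lower number here means a stronger inhibitor, a higher number a weaker inhibitor), compound 1 gives 112000 nM and compound 2 gives 59900 nM. Compound 3 `O=C(O)c1cn(-c2ccc(F)cc2)c2nc(N3CCN(C(c4ccccc4)c4ccc(Cl)cc4)CC3)c([N+](=O)[O-])cc2c1=O` derives from compound 1 by the change (4-fluorophenyl in place of cyclopropyl on an aromatic nitrogen), and the measured step is a 1.1-fold lower number from compound 1 to compound 3 (0.04 log units; within the scatter). In this assay compound 3 gives 102000 nM. Compound 4 `O=C(O)c1cn(-c2ccc(F)cc2)c2nc(N3CCN(C(=O)C4COc5ccccc5O4)CC3)c([N+](=O)[O-])cc2c1=O`, not yet measured, derives from compound 2 by the same change, (4-fluorophenyl in place of cyclopropyl on an aromatic nitrogen), at a place described in identical words. The change has occurred once before in the series, between compound 1 and compound 3. Because a 1.1-fold lower number from compound 1 to compound 3 (0.04 log units; within the scatter) stayed within the scatter, the step from compound 2 to compound 4 in this assay is expected to be comparably small, a 1.1-fold lower number from compound 2 to compound 4 (0.04 log units; within the scatter). Compound 4 is accordingly estimated at 55000 nM, with an expected range from 25000 nM to 120000 nM.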

Compound 4, half-maximal inhibitory concentration: > 54300 nM
Compound 4: a limit, no number; the forecaster's own chance of this, stated with the estimate: 10%; the middle value is on the limit's open side.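

Compound 4 gives a limit and not a number, so no new step from compound 2 to compound 4 can be read: the limit of > 54300 nM in this assay, at which 1 of the 4 values shown sits.

The compounds shown leave open whether 4-fluorophenyl in place of cyclopropyl changes the number when the rest of the structure is that of compound 2.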